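The compounds below may be only part of what the source reports. "The series", "measured", "known", "first", "only" and "open" are said of these compounds alone.

Of the compounds shown here, two have been measured. Compound 1 `Nc1scc(CN2CCN(c3ccccc3C(F)(F)F)CC2)c1C(=O)c1ccc(Cl)cc1` gives 0% in an assay on CHO cells for displacement of a labelled ligand from adenosine receptor A1 (Homo sapiens), read by scintillation counting, with a stated time of 120 min, tested at 10 uM; a lower number here means less inhibition, a higher number more inhibition at the concentration tested (going by the name of the read-out). Compound 2 `Nc1scc(CN2CCN(c3ccncc3)CC2)c1C(=O)c1ccc(Cl)cc1` gives 1% in this assay, and the step of a number 1 percentage points higher from compound 1 to compound 2 (within the scatter) is within the scatter. On these two numbers compound 2 stands highest, with compound 1 nearest and within the scatter of it, so no order between them can be claimed; both sit at the floor of the read-out.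

Compound 3 `Nc1scc(CN2CCN(c3ccc(Cl)c(Cl)c3)CC2)c1C(=O)c1ccc(Cl)cc1` is not yet measured. It differs from compound 2 as follows: 3,4-dichlorophenyl in place of pyridin-4-yl on an amine nitrogen in a ring.

For the measured compounds named here, only one measured step bears on this change, the exchange of the aromatic group on the same ring nitrogen from compound 1 to compound 2, and that step was a number 1 percentage points higher from compound 1 to compound 2 (within the scatter), within the scatter. Two different aromatic groups at this position left the inhibition at the floor, and nothing in the measured data points to a shift in either direction for a third. For compound 3 the expected step is therefore a number 1 percentage points higher from compound 2 to compound 3 (within the scatter), none beyond the scatter. Compound 3 is estimated at 2% in this assay, within a range of -8% to 15%.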

Compound 3, a percentage reported as inhibition, at one concentration (the size of the read-out at that concentration, not a potency): 1%
The estimate for compound 3 lay 1 percentage points above the measured number; the measured number falls inside the stated range.
By their numbers in this assay, from the lowest: compounds 1, 2 and 3 (each within the scatter of the next).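

In this assay, 3,4-dichlorophenyl in place of pyridin-4-yl gives no change at the digits printed from compound 2 to compound 3 (within the scatter), and the same group in place of 2-(trifluoromethyl)phenyl gives a number 1 percentage points higher from compound 1 to compound 3 (within the scatter). The earlier pair had only shown that two aromatic groups on this ring nitrogen leave the read-out at its floor; the new result extends this to a carbon-only ring carrying two chlorine atoms, larger than pyridin-4-yl, and the ring nitrogen and hydrogen-bond acceptor of pyridin-4-yl are not needed to stay at that level. No evidence on why the number stays at the floor accompanies these compounds, so the result stands as an observation for these three groups only.

With all three compounds at the floor, this read-out at the single concentration tested gives no order among the aromatic groups. As far as these compounds go, whether a non-aromatic or more flexible group on the same nitrogen, such as a benzyl, an acetyl or a short alkyl chain, would raise the inhibition remains open, as does any change to the shared core, such as replacing its free amine with an amide.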